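This account rests on a few compounds, and the source may have more. Where it says the series, first, only, none or still open, it means among the compounds named here.

Compound 1 `CCCC(C)C(=O)NCC(C)(C)CC1=C(O)C(=O)c2ccccc2C1=O` was assessed in an ADME assay on Vero cells (Chlorocebus sabaeus) for cytotoxicity, read by reporter gene assay, with a stated time of 4 days (on this read-out lower numbers stand for stronger inhibition and higher numbers for weaker inhibition), where compound 1 gives 48100 nM, the highest of the two numbers measured. Compound 2 `CCCCCCCCC(=O)NCC(C)(C)CC1=C(O)C(=O)c2ccccc2C1=O` gives 16700 nM in this assay, so the step of a 2.9-fold lower number from compound 1 to compound 2 (0.46 log units; beyond the scatter). Compound 3 `CCCCCCC(=O)OCC(C)(C)CC1=C(O)C(=O)c2ccccc2C1=O` is not yet measured; its change from compound 1 is (hexylcarbonyl)oxy in place of ((1-methylbutyl)carbonyl)amino on a saturated chain carbon, three bonds along the chain from a double-bonded ring carbon. Among the compounds with values here, only the step from compound 1 to compound 2 bears on it, and it lowered the number beyond the scatter with a longer chain at the carbonyl carbon. A modest lowering is therefore expected for compound 3, namely a 1.9-fold lower number from compound 1 to compound 3 (0.28 log units; within the scatter), giving an estimated 25000 nM with a range of 10000 nM to 60000 nM.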

Compound 3, half-maximal inhibitory concentration: 99300 nM
Compound 3: middle estimate off by 4.0-fold (0.60 log units), on the low side, and the stated range ends below it.
By their numbers in this assay, from the lowest: compound 2; then compound 1; then compound 3.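

At this saturated chain carbon, (hexylcarbonyl)oxy in place of ((1-methylbutyl)carbonyl)amino gives, in this assay, a 2.1-fold higher number from compound 1 to compound 3 (0.31 log units; beyond the scatter). The direction is opposite to that of the earlier step, which kept the amide link and altered only the chain on the carbonyl carbon, so a longer chain does not lower the number whatever the link. Nothing available explains this rise. The compounds shown leave open whether the link or the chain accounts for it, since both differ in this one exchange, and how a sulfonamide or an amine would read here.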